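A few compounds are considered here, and "the series" means these few. Any claim that something is new, unique, unknown or untested is made for them only; others in the source may bear on it.

Measured in a functional assay on HEK293 cells for agonist activity at Neuronal acetylcholine receptor; alpha4/beta2 (Homo sapiens), read by FLIPR; a lower number here means that less compound is needed, a higher number that more compound is needed for the effect: compound 1 `Cc1cc(N2CC[C@@H]3CN[C@@H]3C2)cnc1Cl` gives 47 nM; compound 2 `N#Cc1cncc(N2CC[C@@H]3CN[C@@H]3C2)c1` gives 1900 nM; compound 3 `CCOc1cncc(N2CC[C@@H]3CN[C@@H]3C2)c1` gives 1350 nM.

Compound 3 stands second highest of the three numbers. The nearest value is joined to it by a 1.4-fold lower number from compound 2 to compound 3 (0.15 log units; within the scatter), a step within the scatter, while the lowest number belongs to compound 1, well beyond the scatter. Compound 4 `Cc1cncc(N2CC[C@@H]3CN[C@@H]3C2)c1` differs from compound 3 by methyl in place of ethoxy on an aromatic carbon. Going by the values given here, the only measured step at the same place is a 1.4-fold lower number from compound 2 to compound 3 (0.15 log units; within the scatter), which was small. Compound 1 also carries a methyl, but with a further change elsewhere, so its value cannot be read as a step. For compound 4 in this assay a modest change is expected, a 2.3-fold lower number from compound 3 to compound 4 (0.35 log units; beyond the scatter), with wide uncertainty. Compound 4 is estimated at 600 nM, range 150 nM to 2500 nM.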

Compound 4, half-maximal effective concentration: 650 nM
For compound 4 the middle estimate is 1.1-fold (0.03 log units) below the measured one; measured number inside the range.
By their numbers in this assay, from the lowest: compound 1; then compound 4; then compounds 3 and 2 (each within the scatter of the next).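

Methyl at this position gives a 2.1-fold lower number from compound 3 to compound 4 (0.32 log units; beyond the scatter) and also a 2.9-fold lower number from compound 2 to compound 4 (0.47 log units; beyond the scatter) in this assay and so separates from ethoxy and cyano, which stay within the scatter of each other. Both steps are modest beside a 14-fold higher number from compound 1 to compound 4 (1.14 log units; beyond the scatter) for hydrogen in place of chloro, so among these compounds the chloro place moves the number more than the methyl place does. No measurement here gives a cause for either step.

Open, as far as these compounds go, is how an amine or a longer chain at this position would compare with methyl. Also open, from the compounds shown here alone, is whether chloro gives a similar step with ethoxy or cyano in place of methyl.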